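The source may report more compounds than this note shows. Statements on the series, on what has been measured and on what is new or still open speak of the compounds shown alone.

Measured so far, in a functional assay on MT4 cells (Homo sapiens) for cytotoxicity; a lower number here means a stronger inhibitor, a higher number a weaker inhibitor:
Compound 1 `N#Cc1c(N)cccc1Sc1cccc(Cl)c1` gives 53000 nM.
Compound 2 `N#Cc1c(N)cccc1Sc1cccc(Br)c1` gives 53000 nM.
Compound 3 `N#Cc1c(N)cccc1S(=O)(=O)c1cccc(Cl)c1` has only a limit, given below.

Compound 1 and compound 2 differ by bromo in place of chloro on an aromatic carbon. The step is no change at the digits printed from compound 1 to compound 2 (within the scatter), so the two halides are indistinguishable here. Compound 3 carries the sulfonyl core; how this core differs from that of compound 1 is not broken down here. In this assay compound 3 reports > 200000 nM, which is a limit of the assay and not a number; this is the limit of > 200000 nM in this assay, at which 1 of the 3 values shown sits.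

Compound 4 `N#Cc1c(N)cccc1S(=O)(=O)c1cccc(Br)c1` is not yet measured. Compound 3 and compound 4 differ by bromo in place of chloro on an aromatic carbon, the same change as between compound 1 and compound 2, at the same place. Since that change produced no change at the digits printed from compound 1 to compound 2 (within the scatter), the step from compound 3 to compound 4 is expected to be a step that the limit leaves unreadable from compound 3 to compound 4, resting on the lack of movement between compound 1 and compound 2. Compound 4 is therefore expected to sit at 250000 nM, most likely again only as a limit, with a range from 150000 nM to 500000 nM.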

Compound 4, half-maximal inhibitory concentration: > 200000 nM
Compound 4 gave a limit, no number; the forecaster's own chance of this, stated with the estimate: 85%; the middle value does not contradict the limit.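

In this assay compound 4 gives > 200000 nM which is a limit of the assay and not a number. Among the compounds shown here, compound 3 also carries only a limit, so no step between compound 3 and compound 4 can be read. Still open, from the compounds shown here alone, is where either compound truly lies, and whether bromo and chloro differ at all on the sulfonyl core.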